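Notes on a hydrazone aryl swap in one series

A few compounds are considered here, and "the series" means these few. Any claim that something is new, unique, unknown or untested is made for them only; others in the source may bear on it.

Three measured compounds share one core, shown for compound 1 as `CCCSc1nc(N/N=C/c2ccc(C)cc2)c2nnn(Cc3ccccc3)c2n1`. In a functional assay on MCF7 cells (Homo sapiens) for antiproliferative activity, read by MTT assay, with a stated time of 72 h (a higher number here means a weaker inhibitor, a lower number a stronger inhibitor), compound 1 gives > 64000 nM, which is a limit of the assay and not a number. Compound 2, `C#CCSc1nc(N/N=C/c2cc(OC)c(OC)c(OC)c2)c2nnn(Cc3ccccc3)c2n1`, differs from compound 1 in more than one place; in this assay compound 2 gives 17000 nM. Compound 3, `CCCSc1nc(N/N=C(\C)c2ccccc2O)c2nnn(Cc3ccc(F)cc3)c2n1`, likewise differs from compound 1 in more than one place. In this assay compound 3 gives > 64000 nM, again a limit. Among the measured compounds shown here, two of the three values shown therefore sit at the limit (the limit of > 64000 nM in this assay, at which 2 of the 3 values shown sit), and compound 1 is one of them, with compound 2 the single numbered value in the set. For the measured compounds named here, no pair of measured compounds differs in only one place, so no measured step is available to size any change.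

Compound 4, `CCCSc1nc(N/N=C/c2c(O)ccc3ccccc23)c2nnn(Cc3ccccc3)c2n1`, differs from compound 1 in one place: 2-hydroxynaphthalen-1-yl in place of 4-methylphenyl on a carbon with a double bond to nitrogen. Without a measured step for this change, the expectation is guarded: a step from the limit of compound 1 toward a numbered value is expected, of the size an at least 2.1-fold lower number from compound 1 to compound 4 (0.32 log units; beyond the scatter), though it may not exceed the scatter. Compound 4 is estimated at 30000 nM, with a range from 8000 nM to 90000 nM, and a fair chance that only a limit is reported.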

Compound 4, half-maximal inhibitory concentration: 6400 nM
Beside the measured number, compound 4's estimate is 4.7-fold (0.67 log units) above it; the whole stated range lies above it.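

In this assay the change from 4-methylphenyl to 2-hydroxynaphthalen-1-yl, on a carbon with a double bond to nitrogen, gives the series its first measured step in one place: an at least 10-fold lower number from compound 1 to compound 4 (1.00 log units; beyond the scatter) with everything else in the core of compound 1 held fixed. Compound 1 gives > 64000 nM here, which is a limit and not a number. This place is therefore shown to respond on its own, something the earlier compounds could not show, and the printed size is only a lower bound because the starting compound sits at that limit: the limit of > 64000 nM in this assay, at which 2 of the 4 values shown sit.

The change brings in the second aromatic ring and the hydroxyl together, so the compounds shown do not tell whether the step needs one of these or both, and a plain naphthalen-1-yl or a 2-aminonaphthalen-1-yl at this place would begin to separate the two. Going by these compounds, the sulfur-linked chain and the benzyl group also remain without a step of their own, and a longer chain on the sulfur is one change whose effect stays unknown.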